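The source may report more compounds than this note shows. Statements on the series, on what has been measured and on what is new or still open speak of the compounds shown alone.

In a toxicity assay on cells (Macrophage, Mus musculus, strain BALB/c) for cytotoxicity, read by MTT assay (on this read-out lower numbers stand for stronger inhibition and higher numbers for weaker inhibition), compound 1 `COc1cc(O)cc(O)c1C(=O)/C=C/c1ccc(Cl)cc1` gives 19000 nM and compound 2 `C=CCOc1cc(OC)c(C(=O)/C=C/c2ccccc2Br)c(OCC=C)c1` gives 5400 nM as the lower of the two numbers, a gap beyond the scatter. Compound 3 `C=CCOc1cc(OC)c(C(=O)/C=C/c2ccc(OC)cc2)c(OCC=C)c1` keeps the core of compound 2 and carries the change 4-methoxyphenyl in place of 2-bromophenyl on a double-bonded chain carbon bound to a double-bonded chain carbon with 4-methoxyphenyl in place of 2-bromophenyl on a double-bonded chain carbon bound to a double-bonded chain carbon. For the measured compounds named here, no single-place step between measured compounds exists as a guide. The expected step of a 1.7-fold higher number from compound 2 to compound 3 (0.22 log units; within the scatter) in this assay is a modest rise in the number, not clearly beyond the scatter. Compound 3 is estimated at 9000 nM with an expected range from 3000 nM to 30000 nM for now.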

Compound 3, half-maximal inhibitory concentration: 18700 nM
Compound 3: middle estimate off by 2.1-fold (0.32 log units), on the low side; low and high end bracket the measured number.
By their numbers in this assay, from the lowest: compound 2; then compounds 3 and 1 (each within the scatter of the next).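

In this assay, for the compounds shown here, the change to 4-methoxyphenyl in place of 2-bromophenyl on a double-bonded chain carbon bound to a double-bonded chain carbon gives the first single-place step, with a 3.5-fold higher number from compound 2 to compound 3 (0.54 log units; beyond the scatter) as its size. The number therefore responds to this position while the rest of the core stays fixed, and the 2-bromophenyl group holds the lower number of this pair. Nothing available accounts for the step.

The step changes both the substituent and its place on the phenyl group, and these two cannot be separated here. Going by these compounds, how an amine or a carboxylic acid on that phenyl group would move the number stays open.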